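Removing the amino group from an ethynyl nucleoside core

The source may report more compounds than this note shows. Statements on the series, on what has been measured and on what is new or still open speak of the compounds shown alone.

Compound 3 `C#Cc1cn([C@@H]2O[C@H](CO)[C@@H](O)[C@H]2O)c2nc(N)nc(OC)c12` carries an ethynyl group and an amino group on its core; in a functional assay on K562 cells (Homo sapiens), read by MTT assay, with a stated time of 72 h (on this read-out higher numbers stand for weaker inhibition and lower numbers for stronger inhibition), compound 3 gives only a limit of > 20000 nM, not a number. It therefore sits at the weak end of the values shown, at the limit (the limit of > 20000 nM in this assay, at which 1 of the 3 values shown sits). Compound 4 `C#Cc1cn([C@@H]2O[C@H](CO)[C@@H](O)[C@H]2O)c2ncnc(OC)c12` differs from it by a single change (hydrogen in place of amino on an aromatic carbon). Among the compounds with values here, no measured pair differs by this change alone. Within the data shown here, the one measured step, a 1.3-fold lower number from compound 1 to compound 2 (0.11 log units; within the scatter), concerns the thiophenyl group on compound 1 `COc1ncnc2c1c(-c1ccsc1)cn2[C@@H]1O[C@H](CO)[C@@H](O)[C@H]1O` and compound 2 `COc1ncnc2c1c(-c1cccs1)cn2[C@@H]1O[C@H](CO)[C@@H](O)[C@H]1O`, and does not bear on the amino group. Those two compounds, which lack the amino group, show that the core without it can be potent: in this assay compound 1 gives 90 nM and compound 2 gives 70 nM, though both carry a thiophenyl group instead of the ethynyl group. On this basis the author expects compound 4 to gain, with an estimated step of an at least 10-fold lower number from compound 3 to compound 4 (1.00 log units; beyond the scatter), and expects compound 4 to reach about 2000 nM, within a range of 100 nM to 20000 nM.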

Compound 4, half-maximal inhibitory concentration: 300 nM
Compound 4: the middle estimate sits 6.7-fold (0.82 log units) above what was measured; the range from low to high includes it.
By their numbers in this assay, from the lowest: compounds 2 and 1 (each within the scatter of the next); then compound 4. At a limit, above all of these: compound 3.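

In this assay, hydrogen in place of amino on the aromatic carbon between two ring nitrogen atoms brings an at least 66-fold lower number from compound 3 to compound 4 (1.82 log units; beyond the scatter) with the ethynyl group in place. This step has only a lower bound, as compound 3 gives a limit and not a number: the limit of > 20000 nM in this assay, at which 1 of the 4 values shown sits. On the core without the amino group, ethynyl in place of thiophen-2-yl gives a 4.3-fold higher number from compound 2 to compound 4 (0.63 log units; beyond the scatter) and ethynyl in place of thiophen-3-yl gives a 3.3-fold higher number from compound 1 to compound 4 (0.52 log units; beyond the scatter) in the same assay, so compound 4 comes near the two thiophenyl compounds but stays modestly short of them.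

The compounds shown leave open whether the amino group has a similar effect on a core carrying a thiophenyl group. They also leave open whether a methylamino group or a hydroxyl group at this position would behave more like amino or like hydrogen.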